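Nitro Enters Where Both Measured Compounds Sit at the Limit

A few compounds are considered here, and "the series" means these few. Any claim that something is new, unique, unknown or untested is made for them only; others in the source may bear on it.

Compound 1 `COc1cc2ccc(=O)oc2cc1OC(=O)c1c(C)noc1-c1ccccc1F` and compound 2 `COc1cc2ccc(=O)oc2cc1OC(=O)c1c(C)noc1-c1ccccc1` share one core and differ only in one aromatic substituent. In a functional assay on Huh-7 cells (Homo sapiens) for inhibition, read by MTT assay, with a stated time of 48 h (on this read-out lower numbers stand for stronger inhibition and higher numbers for weaker inhibition), compound 1 gives only a limit, > 25000 nM. Compound 2 likewise gives only a limit in this assay, > 25000 nM. The step that the two limits leave unreadable from compound 1 to compound 2 cannot be read, since both values stand at the limit of > 25000 nM in this assay, at which 2 of the 2 values shown sit. Compound 3 `COc1cc2ccc(=O)oc2cc1OC(=O)c1c(C)noc1-c1ccc([N+](=O)[O-])cc1` differs from compound 2 by nitro in place of hydrogen on an aromatic carbon. For the measured compounds named here, no measured step bears on this change. Compound 3 is therefore expected to remain at the limit, with an estimated step that the limit leaves unreadable from compound 2 to compound 3. Compound 3 is estimated at 30000 nM, between 8000 nM and 100000 nM.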

Compound 3, half-maximal inhibitory concentration: 8760 nM
Compound 3: middle estimate off by 3.4-fold (0.53 log units), on the high side; the measured number falls inside the stated range.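

In this assay, the change from phenyl to 4-nitrophenyl gives an at least 2.8-fold lower number from compound 2 to compound 3 (0.45 log units; beyond the scatter), so this place on the aromatic ring can move the read-out, which the earlier pair could not show. Putting 4-nitrophenyl in place of 2-fluorophenyl gives an at least 2.8-fold lower number from compound 1 to compound 3 (0.45 log units; beyond the scatter). Compound 3 is thus the only compound shown with a number rather than a limit: the limit of > 25000 nM in this assay, at which 2 of the 3 values shown sit.

From the compounds shown here alone, the true size of both steps stays open, since each starts from a limit. Also open, going by these compounds, is whether an amine or a carboxylic acid at this same place would lower the number as nitro does.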